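The compounds below may be only part of what the source reports. "The series", "measured", "known", "first", "only" and "open" are said of these compounds alone.

Series notes. In a functional assay on HepG2 cells (Homo sapiens) for antiproliferative activity, with a stated time of 72 h (on this read-out lower numbers stand for an effect already at smaller amounts and higher numbers for an effect only at larger amounts of compound), compound 1 `C=CCNC(=O)n1c(-c2ccc(OC)cc2)cc(=O)c2c(OC)cc(OC)cc21` gives only a limit of > 20000 nM. Compound 2 `COc1ccc(-c2cc(=O)c3c(OC)cc(OC)cc3n2S(=O)(=O)c2ccc(C=O)cc2)cc1` likewise returns only a limit, > 34400 nM. Compound 3 `COc1ccc(-c2cc(=O)c3c(OC)cc(OC)cc3n2S(=O)(=O)c2ccc(Cl)cc2)cc1` also stands at a limit, > 34400 nM. Compound 3 therefore sits among three compounds without a numerical value, and the steps a step that the two limits leave unreadable from compound 1 to compound 2, a step that the two limits leave unreadable from compound 1 to compound 3 and a step that the two limits leave unreadable from compound 2 to compound 3 cannot be sized because every value rests at the limit of > 20000 nM in this assay, at which 1 of the 3 values shown sits, or (the limit of > 34400 nM in this assay, at which 2 of the 3 values shown sit).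

Compound 4 `COc1ccc(-c2cc(=O)c3c(OC)cc(OC)cc3n2S(=O)(=O)c2cccc(Br)c2)cc1` differs from compound 3 by 3-bromophenyl in place of 4-chlorophenyl on a sulfonyl sulfur. Within the data shown here, the one measured step that touches the group on the sulfonyl sulfur, a step that the two limits leave unreadable from compound 2 to compound 3, is unreadable between two limits, so it neither supports nor excludes a shift of any size in this assay. On that basis compound 4 is expected to remain at the limit of this assay, with an estimated step that the limit leaves unreadable from compound 3 to compound 4 that cannot be told from none. The estimate for compound 4 is 40000 nM, within 10000 nM to 150000 nM.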

Compound 4, half-maximal effective concentration: > 58600 nM
Compound 4 gave a limit, no number (the forecaster's own chance of this, stated with the estimate: 85%); at least 1.4-fold (0.16 log units) between middle value and limit.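

In this assay compound 4 gives > 58600 nM, a limit and not a number. Its steps from compound 1, compound 2 and compound 3 therefore cannot be read. The compounds shown leave open whether any group on the aromatic nitrogen of the shared core gives a measurable value.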